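The compounds below may be only part of what the source reports. "The series", "measured", "known", "first", "only" and "open" are said of these compounds alone.

Measured compounds and values:

Compound 1, `N/C(=N\NC(=S)N1CCCCCC1)c1ccccn1`, 86.5%
Compound 2, `N/C(=N\NC(=S)N1CCSCC1)c1ccccn1`, 83.9%
Compound 3, `N/C(=N\NC(=S)N1CCSCC1)c1ccc(F)cn1`, 70.9%

In a functional assay on A-375 cells (Homo sapiens) for cytotoxicity, read by MTT assay, with a stated time of 72 h, tested at 10 uM (on this read-out higher numbers stand for more inhibition of growth at the one concentration tested and lower numbers for less inhibition of growth), compound 1 gives 86.5%. Compound 2 gives 83.9%, a value that lies within the scatter of the number for compound 1, so the two are not separated by this read-out. How the core of compound 1 differs from that of compound 2 is not broken down here. Compound 3 gives 70.9% in this assay; the step of a number 13 percentage points lower from compound 2 to compound 3 (beyond the scatter) goes with the change (fluoro in place of hydrogen on an aromatic carbon).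

Compound 4, `N/C(=N\NC(=S)N1CCCCCC1)c1ccc(F)cn1`, has not yet been measured. It differs from compound 1 by fluoro in place of hydrogen on an aromatic carbon, the same change that separates compound 2 from compound 3, made on the other core. For the measured compounds named here, the expected step for compound 4 is a number 13.5 percentage points lower from compound 1 to compound 4 (beyond the scatter), and this expectation rests on the one measured example of the change, a number 13 percentage points lower from compound 2 to compound 3 (beyond the scatter), applied to the value of compound 1, 86.5%. On that basis compound 4 is estimated at 73% in this assay, with a likely range from 60% to 85%.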

Compound 4, percent growth inhibition at one concentration: 72.2%
The estimate for compound 4 lay 0.8 percentage points above the measured number, and the stated range covers the measured number.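

Putting fluoro in place of hydrogen on an aromatic carbon, para to a large group, gives a number 14.3 percentage points lower from compound 1 to compound 4 (beyond the scatter) in this assay. Set beside the earlier case, the change carries over from one core to the other with its size kept: the same change on two cores in this assay, a number 13 percentage points lower (beyond the scatter) from compound 2 to compound 3 and a number 14.3 percentage points lower (beyond the scatter) from compound 1 to compound 4, 1.3 percentage points apart, within the scatter of two such steps

For the compounds shown here, this rests on only two matched pairs, read at one concentration on one cell line, so it shows agreement on these two cores alone. It does not show that the step would keep its size on any other core, and it does not explain why the number falls.

At this place on the ring the compounds shown carry only hydrogen or fluoro, which leaves open whether chloro, methoxy or an amine there would give a step of similar size. Also open, going by these compounds, is how the fluoro step would look on a core carrying a carboxylic acid or a longer chain.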